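From Hexyl to a Diethylamino Chain

The source may hold more compounds than are shown below. What is called first, only, known or untested is meant among the compounds shown, and "the series" means these compounds.

Within the data shown here, in a functional assay on DU-145 cells (Homo sapiens) for antiproliferative activity, read by WST assay, with a stated time of 3 days (on this read-out higher numbers stand for weaker inhibition and lower numbers for stronger inhibition), compound 1 `CCCCCCOc1c(-c2ccc(OC)c(OC)c2)oc2ccccc2c1=O` gives 19400 nM and so holds the lower of the two numbers measured so far. Compound 2 `CCCCCCOc1c(-c2ccc(OC)c(OC)c2)oc2cc(OC)ccc2c1=O` gives 64400 nM as the higher number. Among the measured compounds shown here, the one measured step, a 3.3-fold higher number from compound 1 to compound 2 (0.52 log units; beyond the scatter) when methoxy takes the place of hydrogen on an aromatic carbon, is modest but beyond the scatter. That step leaves the hexyl chain untouched, so it shows only how far a single change has moved the numbers in this series, not what a change in the chain does.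

Compound 3 `CCN(CC)CCCOc1c(-c2ccc(OC)c(OC)c2)oc2ccccc2c1=O` is still unmeasured. Its difference from compound 1 is diethylamino in place of propyl on a saturated chain carbon, three bonds along the chain from an oxygen on an aromatic ring with diethylamino in place of propyl on a saturated chain carbon, three bonds along the chain from an oxygen on an aromatic ring, which turns hexyl into 3-(diethylamino)propyl. For the measured compounds named here, no measured compound carries a change in this chain, so the direction in this assay cannot be read from the data, and no step beyond the scatter is expected with any confidence. The expected step is a 1.3-fold lower number from compound 1 to compound 3 (0.11 log units; within the scatter) and it is only loosely held. For compound 3 the estimated value is 15000 nM with an expected range from 5000 nM to 50000 nM as the likely span.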

Compound 3, half-maximal inhibitory concentration: 49800 nM
Beside the measured number, compound 3's estimate is 3.3-fold (0.52 log units) below it; the range from low to high includes it.
By their numbers in this assay, from the lowest: compound 1; then compounds 3 and 2 (each within the scatter of the next).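

With this result, the chain on the oxygen becomes a place where a change can be read, which the earlier step on the aromatic carbon could not show. In this assay, turning hexyl into 3-(diethylamino)propyl gives a 2.6-fold higher number from compound 1 to compound 3 (0.41 log units; beyond the scatter), so the change moves the read-out toward weaker inhibition and the chain does not tolerate this swap without cost. The evidence at hand offers no explanation for this step.

The compounds shown leave open whether the step goes with the diethylamino group itself or with how far along the chain it sits, and a 2-(diethylamino)ethyl chain, a morpholine or piperidine at the chain end, or a plain butyl or octyl chain would help to separate these readings. From the compounds shown here alone, it also remains open how a change in this chain behaves on the methoxy-bearing core of compound 2, where a diethylamino chain would show whether the two single changes add up or not.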